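Trimming the Fluorines of a Glycine Transporter Inhibitor

The compounds below may be only part of what the source reports. "The series", "measured", "known", "first", "only" and "open" are said of these compounds alone.

Going by the values given here, compound 1 `CCCS(=O)(=O)N1CCC(CNC(=O)c2c(F)ccc(Cl)c2F)(C(=O)N2CCOCC2)CC1` is the only compound here with a measured number: in an assay on isolated protein for inhibition of sodium- and chloride-dependent glycine transporter 1 (Rattus norvegicus) (on this read-out higher numbers stand for weaker inhibition and lower numbers for stronger inhibition), compound 1 gives 19.7 nM. Compound 2 `CCCS(=O)(=O)N1CCC(CNC(=O)c2ccc(Cl)cc2Cl)(C(=O)NCC)CC1` has no result in this assay, where compound 2 is recorded as "not determined" (no result reported), so compound 1 stands alone. Compound 3 `CCCS(=O)(=O)N1CCC(CNC(=O)c2ccccc2Cl)(C(=O)N2CCOCC2)CC1` differs from compound 1 in one place: 2-chlorophenyl in place of 3-chloro-2,6-difluorophenyl on a carbonyl carbon. Among the compounds with values here, no measured pair shows what such a change does, so the forecast rests on compound 1 alone. The step of a 3.0-fold higher number from compound 1 to compound 3 (0.48 log units; beyond the scatter) is expected to be a modest weakening, a little beyond the usual scatter. Compound 3 is therefore estimated at 60 nM, with a likely range from 15 nM to 250 nM.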

Compound 3, half-maximal inhibitory concentration in the sodium- and chloride-dependent glycine transporter 1 assay: 18.3 nM
Compound 3: middle estimate off by 3.3-fold (0.52 log units), on the high side; low and high end bracket the measured number.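

In the sodium- and chloride-dependent glycine transporter 1 assay, 2-chlorophenyl in place of 3-chloro-2,6-difluorophenyl on the carbonyl carbon gives a 1.1-fold lower number from compound 1 to compound 3 (0.03 log units; within the scatter), so at this position a group without any fluorine holds the inhibition of compound 1, something a single measured compound could not show. In a physicochemical assay for lipophilicity (on this read-out lower numbers stand for lower lipophilicity and higher numbers for higher lipophilicity), compound 1 gives < 1.4, which is a limit of the assay. In the physicochemical assay compound 3 gives < 1.4, again a limit and not a number.

The step between these two compounds on that read-out cannot be read, because both sit at the same limit: the limit of < 1.4 in the physicochemical assay, at which 2 of the 2 values shown sit. As far as these compounds go, whether an unsubstituted phenyl, or a nitrile in place of the chlorine, would hold the same inhibition stays open.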